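Cytotoxicity of an aminopyrimidine series on murine cells

The source may hold more compounds than are shown below. What is called first, only, known or untested is meant among the compounds shown, and "the series" means these compounds.

Three compounds sharing the trifluoromethoxy-aniline motif were tested in an ADME assay on BaF3 cells (Mus musculus) for cytotoxicity; on this read-out lower numbers stand for an effect already at smaller amounts and higher numbers for an effect only at larger amounts of compound. Compound 1 `CC(C)Cn1cc(-c2cc(Nc3ccc(OC(F)(F)F)cc3)ncn2)cn1` reaches only the assay limit, giving > 10000 nM. Compound 2 `O=C(NCCO)c1cc2c(Nc3ccc(OC(F)(F)F)cc3)ncnc2s1` likewise reaches only the limit, with > 10000 nM. Compound 3 `FC(F)(F)Oc1ccc(Nc2ncnc3nn(C4CCCCC4)cc23)cc1` also sits at the limit, at > 10000 nM. Compound 1 therefore stands where every other value stands, since the limit of > 10000 nM in this assay, at which 3 of the 3 values shown sit, holds for all three. Compound 4 `FC(F)(F)Oc1ccc(Nc2cc(-c3ccnc4[nH]ccc34)ncn2)cc1` is not yet measured; it differs from compound 1 by a group of 9 heavy atoms (7 carbon, 2 nitrogen; one five-membered aromatic ring with 1 hetero atom, one six-membered aromatic ring with 1 hetero atom) in place of a group of 9 heavy atoms (7 carbon, 2 nitrogen; one five-membered aromatic ring with 2 hetero atoms), on an aromatic carbon. Going by the values given here, no measured step is available to guide this change, and with all three values at the limit no direction can be read from them. Compound 4 is expected to remain near that limit, with an estimated step of a number no higher from compound 1 to compound 4 (the limit leaves the size open) not beyond the scatter. Compound 4 is thus estimated at 10000 nM, within 3000 nM to 30000 nM.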

Compound 4, half-maximal effective concentration: 6850 nM
Beside the measured number, compound 4's estimate is 1.5-fold (0.16 log units) above it; the range from low to high includes it.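

In this assay the exchange of 1-isobutyl-1H-pyrazol-4-yl for a group with one five-membered and one six-membered aromatic ring gives an at least 1.4-fold lower number from compound 1 to compound 4 (0.16 log units; that floor lies within the scatter) and makes compound 4 the only compound shown with a number rather than a limit. Going by these compounds, a change at this aromatic carbon can therefore yield a value that can be read, but the true size of the step stays open: the limit of > 10000 nM in this assay, at which 3 of the 4 values shown sit.

The compounds shown leave open whether the hydrogen-bond donor of the entering group matters here. They also leave open how a phenyl ring or an amine would read at this place.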